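From Octylsulfanyl to Butoxy on a Shared Core

The compounds below may be only part of what the source reports. "The series", "measured", "known", "first", "only" and "open" are said of these compounds alone.

Compound 1 `CCOc1nc(N)nc2c1ncn2/C=C1/CC1(CO)CO` carries an ethoxy group on an aromatic carbon of the shared core. In an ADME assay on Akata cells (Homo sapiens) for cytotoxicity, with a stated time of 7 days (on this read-out higher numbers stand for lower toxicity in this test and lower numbers for higher toxicity in this test), compound 1 gives only a limit, > 20000 nM. Compound 2 `CCCCCCCCSc1nc(N)nc2c1ncn2/C=C1/CC1(CO)CO` carries octylsulfanyl in place of that ethoxy. In this assay compound 2 likewise gives only a limit, > 20000 nM. The step that the two limits leave unreadable from compound 1 to compound 2 therefore cannot be read in size or direction, since both of its values sit at the limit of > 20000 nM in this assay, at which 2 of the 2 values shown sit. Compound 3 `CCCCOc1nc(N)nc2c1ncn2/C=C1/CC1(CO)CO` is the compound still to be measured; it differs from compound 2 by butoxy in place of octylsulfanyl on an aromatic carbon. For the measured compounds named here, the one measured step, from ethoxy to octylsulfanyl, bears on this change, as it too alters the chain on an aromatic carbon of the core, but its size is not readable. With both measured compounds at the limit, compound 3 is expected to remain there as well, with a step that the limit leaves unreadable from compound 2 to compound 3 that should not exceed the scatter. Compound 3 is estimated at 30000 nM, between 15000 nM and 100000 nM, and the test is expected most likely to report a limit once more.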

Compound 3, half-maximal cytotoxic concentration: > 20000 nM
Compound 3 was reported as a limit; the forecaster's own chance of this, stated with the estimate: 85%; the middle value lies beyond the limit too.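

In this assay compound 3 gives > 20000 nM as a limit only. For the compounds shown here, no new step among compound 1, compound 2 and compound 3 can be read in size or direction, as all three sit at one limit: the limit of > 20000 nM in this assay, at which 3 of the 3 values shown sit. The compounds shown leave open whether the ethoxy, butoxy and octylsulfanyl chains differ at all on this read-out.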